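The source may report more compounds than this note shows. Statements on the series, on what has been measured and on what is new or still open speak of the compounds shown alone.

Measured so far in a functional assay on WiDr cells (Homo sapiens) for inhibition, read by sulforhodamine B assay, with a stated time of 48 h; a higher number here means a weaker inhibitor of growth, a lower number a stronger inhibitor of growth:
compound 1 `COC(=O)[C@@]1(C)CCC=C2[C@@H]1CC[C@@H](C)[C@]2(C)Cc1c[nH]c2ccc(Br)cc12` gives 20000 nM;
compound 2 `COC(=O)[C@@]1(C)CCC=C2[C@@H]1CC[C@@H](C)[C@]2(C)Cc1c[nH]c2ccc(Cl)cc12` gives 20000 nM;
compound 3 `COC(=O)[C@@]1(C)CCC=C2[C@@H]1CC[C@@H](C)[C@]2(C)Cc1c(C)[nH]c2ccc(Br)cc12` gives 15000 nM.

Compound 2 and compound 1 are related by chloro in place of bromo on an aromatic carbon, and this change made the step of no change at the digits printed from compound 1 to compound 2 (within the scatter). Compound 3 and compound 1 differ in the core by methyl in place of hydrogen on an aromatic carbon, with the step of a 1.3-fold lower number from compound 1 to compound 3 (0.12 log units; within the scatter).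

Compound 4 `COC(=O)[C@@]1(C)CCC=C2[C@@H]1CC[C@@H](C)[C@]2(C)Cc1c(C)[nH]c2ccc(Cl)cc12` is not yet measured in this assay. It is related to compound 3 by chloro in place of bromo on an aromatic carbon, the same change that relates compound 2 to compound 1, at a place described in the same words. The step from compound 3 to compound 4 is expected to be no change at the digits printed from compound 3 to compound 4 (within the scatter), resting on the step of no change at the digits printed from compound 1 to compound 2 (within the scatter) made by the same change from compound 1 to compound 2. Compound 4 is therefore estimated at 15000 nM, with a range from 7500 nM to 30000 nM.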

Compound 4, concentration for 50% growth inhibition: 18000 nM
Estimate against measurement, compound 4: 1.2-fold (0.08 log units) below; the measured number falls inside the stated range.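

In this assay chloro in place of bromo on the core carrying the added methyl gives a 1.2-fold higher number from compound 3 to compound 4 (0.08 log units; within the scatter) and stays in line with the earlier step: the same change on two cores in this assay, no change at the digits printed (within the scatter) from compound 1 to compound 2 and a 1.2-fold higher number (0.08 log units; within the scatter) from compound 3 to compound 4, 1.2-fold (0.08 log units) apart, within the scatter of two such steps.
Methyl in place of hydrogen on an aromatic carbon, carried to the chloro core, gives a 1.1-fold lower number from compound 2 to compound 4 (0.05 log units; within the scatter) and also stays in line with the earlier step: the same change on two cores in this assay, a 1.3-fold lower number (0.12 log units; within the scatter) from compound 1 to compound 3 and a 1.1-fold lower number (0.05 log units; within the scatter) from compound 2 to compound 4, 1.2-fold (0.08 log units) apart, within the scatter of two such steps.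
Both changes therefore carry across these two cores without a detectable shift, but every step lies within the scatter, so this shows only agreement between small steps, not that a change of real size would carry over in the same way.

As far as these compounds go, whether an amine or a nitrile in place of the halogen, or a longer chain in place of the methyl, would move the number remains open. So does the effect of a carboxylic acid in place of the methyl ester.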